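The compounds below may be only part of what the source reports. "The series", "measured", "known", "first", "only" and "open" are said of these compounds alone.

Measured so far:
- compound 1 `CNC(=O)[C@@]12C[C@@H]1[C@@H](n1cnc3c(NCc4cccc(Cl)c4)nc(C#CCCCCc4cn(-c5cccc([N+](=O)[O-])c5)nn4)nc31)[C@H](O)[C@@H]2O`: 10.6 nM
- compound 2 `CNC(=O)[C@@]12C[C@@H]1[C@@H](n1cnc3c(NCc4cccc(Cl)c4)nc(C#CCCCCc4cn(CCCCCCC(=O)NCCOCOCOCOCNC5SCC6NC(=O)NC65)nn4)nc31)[C@H](O)[C@@H]2O`: 235 nM

In an assay on CHO cells for displacement of a labelled ligand from adenosine receptor A3 (Homo sapiens), read by scintillation counting (on this read-out higher numbers stand for weaker inhibition and lower numbers for stronger inhibition), compound 1 gives 10.6 nM and stands lowest of the two numbers; compound 2 gives 235 nM, a gap that lies beyond the scatter. Within the data shown here, no step between two measured compounds differing in one place is available, so the effect of a change on the aromatic nitrogen of the five-membered ring cannot be read from a measured pair.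

Compound 3 `CNC(=O)[C@@]12C[C@@H]1[C@@H](n1cnc3c(NCc4cccc(Cl)c4)nc(C#CCCCCc4cn(CCNC(C)=O)nn4)nc31)[C@H](O)[C@@H]2O` is not yet measured. It differs from compound 1 by 2-acetamidoethyl in place of 3-nitrophenyl on an aromatic nitrogen.

Among the measured compounds shown here, the only comparison at hand is compound 1 against compound 2, where a large group on that nitrogen goes with a weaker number. The 2-acetamidoethyl group is much smaller than what enters in compound 2, so a modest loss is expected rather than a large one: the step of a 2.8-fold higher number from compound 1 to compound 3 (0.45 log units; beyond the scatter) is expected to be small, in the direction of a higher number, and may not exceed the scatter. Compound 3 is estimated at 30 nM, within 8 nM to 120 nM.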

Compound 3, inhibition constant: 22.3 nM
The estimate for compound 3 lay 1.3-fold (0.13 log units) above the measured number; low and high end bracket the measured number.
By their numbers in this assay, from the lowest: compound 1; then compound 3; then compound 2.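

In this assay, among these compounds, the first measured pair at this position gives a 2.1-fold higher number from compound 1 to compound 3 (0.32 log units; beyond the scatter), a modest step, for 2-acetamidoethyl in place of 3-nitrophenyl on the aromatic nitrogen of the five-membered ring. With compound 3 at 22.3 nM, a six-membered aromatic ring on this nitrogen is not required for a number of this order, although the change does carry a cost beyond the scatter. No measurement at hand accounts for the size of this step.

Still open, going by these compounds, is whether the step follows the loss of the ring or the entry of the amide chain; a plain phenyl or a 2-aminoethyl group on the same nitrogen would separate the two. Also open, on these data alone, is whether a longer chain ending in an acetamide or a carboxylic acid would stay near compound 3.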